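Working notes: the step from compound 2 to compound 4

A few compounds are considered here, and "the series" means these few. Any claim that something is new, unique, unknown or untested is made for them only; others in the source may bear on it.

Three compounds of the series have numbers in a functional assay on SGC-7901 cells (Homo sapiens) for inhibition, read by MTT assay, with a stated time of 72 h; on this read-out higher numbers stand for weaker inhibition of growth and lower numbers for stronger inhibition of growth. Compound 1 `COC1=C(C)C(=O)C(CCCCCCCCCCn2cc(C[C@H](O)COCCOC[C@@H](O)Cc3ccc(-c4ccccc4)cc3)nn2)=C(C)C1=O` gives 505 nM, compound 3 `O[C@H](COCCOC[C@@H](O)Cc1cn(Cc2ccc(Oc3ccccc3)cc2)nn1)Cc1ccc(-c2ccccc2)cc1` gives 4500 nM, and compound 2 `O=C1COc2ccc(-n3cc(C[C@H](O)COCCOC[C@@H](O)Cc4ccc(-c5ccccc5)cc4)nn3)cc2N1` gives 15200 nM. Compound 2 has the highest number of the three and is therefore the weakest growth inhibitor so far. Compound 3 lies nearest to it and compound 1 furthest, both beyond the usual scatter.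

Compound 4 `O[C@H](COCCOC[C@@H](O)Cc1cn(-c2cncnc2)nn1)Cc1ccc(-c2ccccc2)cc1` has not yet been measured. It keeps the shared core and carries pyrimidin-5-yl: a group of 6 heavy atoms (4 carbon, 2 nitrogen; one six-membered aromatic ring with 2 hetero atoms) in place of a group of 11 heavy atoms (8 carbon, 1 nitrogen, 2 oxygen; one six-membered non-aromatic ring with 2 hetero atoms, one six-membered aromatic ring of carbon only), on an aromatic nitrogen.

For the measured compounds named here, no measured pair differs in one place only, so the size of this step cannot be read from a direct precedent. The three measured values show that the group on this nitrogen can go with large differences in this assay, but they give no sign of a gain from pyrimidin-5-yl. The expectation therefore starts from compound 2 at 15200 nM, with no step beyond the scatter and a slight lean towards a higher number. The estimated step is a 1.3-fold higher number from compound 2 to compound 4 (0.12 log units; within the scatter). For compound 4 the expected value is 20000 nM, with an estimated range of 7000 nM to 50000 nM.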

Compound 4, concentration for 50% growth inhibition: > 100000 nM
Compound 4 ended at the assay's limit; the forecaster's own chance of this, stated with the estimate: 15%; middle value at least 5.0-fold (0.69 log units) from the limit.
By their numbers in this assay, from the lowest: compound 1; then compound 3; then compound 2. At a limit, above all of these: compound 4.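

In this assay compound 4 gives > 100000 nM, which is a limit of the assay and not a number: the limit of > 100000 nM in this assay, at which 1 of the 4 values shown sits.

For the compounds shown here, putting pyrimidin-5-yl in place of the group of 11 heavy atoms on the aromatic nitrogen gives an at least 6.5-fold higher number from compound 2 to compound 4 (0.81 log units; beyond the scatter), so this is the first single-place change with a readable step, and it lies beyond the scatter with its full size unknown. Going by these compounds alone, it also shows that this nitrogen does not accept every aromatic group equally: compound 2 already had the highest number among the earlier compounds, yet this exchange still moves the read-out further, to a place above all three of them.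

The compounds shown do not separate the loss of heavy atoms from the presence of the two ring nitrogens in pyrimidin-5-yl, and they give no cause for the step. A plain phenyl or a pyridin-3-yl on the same nitrogen would address that question, while a longer chain ending in pyrimidin-5-yl would test whether this ring is tolerated further from the aromatic nitrogen.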